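Aryl change on the triazole nitrogen of compound 3

The source may hold more compounds than are shown below. What is called first, only, known or untested is meant among the compounds shown, and "the series" means these compounds.

Among the compounds with values here, compound 3 `Cc1c(C(=O)Nc2ccc(Oc3ccnc4[nH]ccc34)cc2)nnn1-c1ccccc1` gives 320 nM in a functional assay on MCF7 cells (Homo sapiens) for cytotoxicity, read by MTT assay, with a stated time of 72 h (on this read-out higher numbers stand for weaker inhibition and lower numbers for stronger inhibition), one of only two numbers available here. Compound 1 `Cc1c(C(=O)Nc2ccc(Oc3ccnc4[nH]ccc34)c(F)c2)nnn1-c1ccccc1` gives 350 nM, and the step of a 1.1-fold lower number from compound 1 to compound 3 (0.04 log units; within the scatter) is within the scatter, so the two stand together. Compound 2 `COc1ccc(-n2nnc(C(=O)Nc3ccc(Oc4ccnc5[nH]ccc45)c(F)c3)c2C)cc1` gives "not determined" (no result reported) in this assay. Compound 4 `Cc1c(C(=O)Nc2ccc(Oc3ccnc4[nH]ccc34)cc2)nnn1-c1ccc(Cl)c(C(F)(F)F)c1` carries 4-chloro-3-(trifluoromethyl)phenyl in place of phenyl on an aromatic nitrogen. Within the data shown here, no measured step touches the group on this aromatic nitrogen: the only step available concerns the fluoro and is within the scatter. The data give no size or direction for this change, so the expectation is wide. Compound 4 is expected at 180 nM, with a range of 40 nM to 900 nM. The step of a 1.8-fold lower number from compound 3 to compound 4 (0.25 log units; within the scatter) is estimated as modest and uncertain.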

Compound 4, half-maximal inhibitory concentration: 8410 nM
Compound 4: middle estimate off by 47-fold (1.67 log units), on the low side, outside the stated range (above it).
By their numbers in this assay, from the lowest: compounds 3 and 1 (each within the scatter of the next); then compound 4.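

In this assay, within the data shown here, the group on this aromatic nitrogen proves to be a sensitive point: 4-chloro-3-(trifluoromethyl)phenyl in place of phenyl gives a 26-fold higher number from compound 3 to compound 4 (1.42 log units; beyond the scatter), whereas the only earlier step, at the fluoro, stayed within the scatter. The larger aryl group is therefore not tolerated here in the way phenyl is. No measurement bears on the reason for this loss.

As far as these compounds go, it remains open whether the chloro alone or the trifluoromethyl alone would carry this step. Also open, from the compounds shown here alone, is how an aryl group bearing an amine, or a cyclohexyl ring, would behave at this position.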